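Benzyl and furan-2-yl amides, with a bromine still to test

The source may report more compounds than this note shows. Statements on the series, on what has been measured and on what is new or still open speak of the compounds shown alone.

Values in a functional assay on A2780 cells (Homo sapiens) for antiproliferative activity, read by resazurin assay, with a stated time of 72 h; a lower number here means a stronger inhibitor, a higher number a weaker inhibitor:
- Compound 1 `NC(=O)c1cc2c(Cc3ccccc3)n[nH]c2cc1O`: "not determined" (no result reported)
- Compound 2 `CN(Cc1ccccc1)C(=O)c1cc2c(Cc3ccccc3)n[nH]c2cc1O`: 980 nM
- Compound 3 `CN(C(=O)c1cc2c(Cc3ccccc3)n[nH]c2cc1O)c1ccco1`: 2500 nM

Within the data shown here, compound 1 has no number, so only two compounds can be compared. Of these, compound 3 has the higher number, 2500 nM, and is the weaker inhibitor.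

The next compound is compound 4 `CN(Cc1ccccc1Br)C(=O)c1cc2c(Cc3ccccc3)n[nH]c2cc1O`, with 2-bromobenzyl in place of furan-2-yl on an amide-type nitrogen.

Among the measured compounds shown here, one measured step bears on this change: a 2.6-fold higher number from compound 2 to compound 3 (0.41 log units; beyond the scatter). That step put furan-2-yl in place of benzyl at the same nitrogen. For the measured compounds named here, the new change runs the other way, back to a benzyl group, though this one carries a bromine, and no measured compound shows what the bromine does. A modest step toward a lower number is therefore expected, of about the size of the measured one, with wide uncertainty.

The expected step is a 2.5-fold lower number from compound 3 to compound 4 (0.40 log units; beyond the scatter).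

For compound 4 the estimated value is 1000 nM, with an expected range from 400 nM to 2500 nM.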

Compound 4, half-maximal inhibitory concentration: 1200 nM
The estimate for compound 4 lay 1.2-fold (0.08 log units) below the measured number; the range from low to high includes it.
By their numbers in this assay, from the lowest: compounds 2 and 4 (each within the scatter of the next); then compound 3.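

In this assay, 2-bromobenzyl in place of furan-2-yl on the amide-type nitrogen gives a 2.1-fold lower number from compound 3 to compound 4 (0.32 log units; beyond the scatter), so the return from the furan-2-yl amide to a benzyl-type group holds with a bromine on the aromatic ring as well as without one. The effect of the bromine can now be read directly: bromo in place of hydrogen on an aromatic carbon gives a 1.2-fold higher number from compound 2 to compound 4 (0.09 log units; within the scatter), which leaves compound 2 and compound 4 indistinguishable in this assay. Nothing shown here accounts for these numbers.

On these data alone, whether the same holds for bromine at other places on the benzyl ring remains open. So does the outcome with an amine or a carboxylic acid on that ring, or with a longer chain between the ring and the amide-type nitrogen.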